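The source may hold more compounds than are shown below. What is called first, only, known or untested is meant among the compounds shown, and "the series" means these compounds.

The series shares one core, varied only at the ring nitrogen. Compound 1 `CCCCN1CCc2nc(C#Cc3ccccc3)sc2C1` carries a butyl group on that nitrogen, and in an assay on HEK293 cells for negative allosteric modulation of metabotropic glutamate receptor 5 (Homo sapiens), read by FLIPR, with a stated time of 1 h (on this read-out higher numbers stand for weaker inhibition and lower numbers for stronger inhibition), compound 1 gives > 10000 nM, which is a limit of the assay rather than a number. Compound 2 `C(#Cc1nc2c(s1)CN(C1CCCCC1)CC2)c1ccccc1` carries a cyclohexyl group there, and in this assay compound 2 likewise gives only a limit, > 10000 nM. Among the measured compounds shown here, compound 3 `CC(=O)N1CCc2nc(C#Cc3ccccc3)sc2C1` carries an acetyl group instead, and in this assay compound 3 gives 90 nM, the only number among the three values shown. The step that the two limits leave unreadable from compound 1 to compound 2 cannot be read because both compounds sit at the limit of > 10000 nM in this assay, at which 2 of the 3 values shown sit. The steps of an at least 110-fold lower number from compound 1 to compound 3 (2.04 log units; beyond the scatter) and an at least 110-fold lower number from compound 2 to compound 3 (2.04 log units; beyond the scatter) are both large. Compound 4 `O=C(C1CC1)N1CCc2nc(C#Cc3ccccc3)sc2C1` differs from compound 3 by cyclopropyl in place of methyl on a carbonyl carbon, so the acetyl becomes cyclopropylcarbonyl and the amide is kept. Neither measured step concerns a change of this kind, as both concern exchange of an alkyl group for the acetyl. For the measured compounds named here, no measured step therefore speaks to its size, and the step of a 1.3-fold lower number from compound 3 to compound 4 (0.11 log units; within the scatter) is expected to stay within the scatter. Compound 4 is accordingly expected to give 70 nM, with a range from 25 nM to 250 nM.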

Compound 4, half-maximal inhibitory concentration: 290 nM
Compound 4: middle estimate off by 4.1-fold (0.62 log units), on the low side; the whole stated range lies below it.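

Earlier steps only exchanged an alkyl group for the acetyl; this one changes what sits on the carbonyl carbon while the amide stays, and in this assay it gives a 3.2-fold higher number from compound 3 to compound 4 (0.51 log units; beyond the scatter), a modest step beyond the scatter. So the read-out responds to the group on that carbonyl carbon, not only to the presence of the amide, yet cyclopropylcarbonyl still stands far from the alkyl groups on the ring nitrogen, with an at least 34-fold lower number from compound 2 to compound 4 (1.53 log units; beyond the scatter) and an at least 34-fold lower number from compound 1 to compound 4 (1.53 log units; beyond the scatter). Both of these large steps are bounds rather than exact sizes, because compound 1 and compound 2 give only a limit of the assay: the limit of > 10000 nM in this assay, at which 2 of the 4 values shown sit.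

With only methyl and cyclopropyl on the carbonyl carbon, the compounds shown cannot separate the ring from the added carbons, so an isopropyl or tert-butyl group there remains an open case. Also open, as far as these compounds go, is how a carbamate, a urea or a sulfonamide on the ring nitrogen would compare with these amides.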